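The source may hold more compounds than are shown below. What is called first, only, known or untested is meant among the compounds shown, and "the series" means these compounds.

Measured compounds:
Compound 1 `COc1ccc(CCOc2ccc(-c3c(C)nc(C)c([C@H](OC(C)(C)C)C(=O)O)c3N3CCC(C)(C)CC3)cc2)cc1`; in an ADME assay on microsomes from liver (Rattus norvegicus) for metabolic stability, read by LC-MS, tested at 0.5 uM (on this read-out lower numbers stand for a shorter-lived compound and higher numbers for a longer-lived compound), compound 1 gives > 2 h, a limit of the assay rather than a number.
Compound 2 `Cc1nc(C)c([C@H](OC(C)(C)C)C(=O)O)c(N2CCC(C)(C)CC2)c1-c1ccc(OCCc2ccc(F)cc2F)cc1`; in this assay compound 2 gives > 2 h, again a limit.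
Compound 3 `Cc1nc(C)c([C@H](OC(C)(C)C)C(=O)O)c(N2CCC(C)(C)CC2)c1-c1ccc(CCCc2ccc(F)cc2)cc1`; in this assay compound 3 gives > 2 h, also a limit.

Compound 2 thus stands at a limit in this assay, and so do the two other measured compounds, so none of the three can be placed above or below another. Compound 4 `Cc1nc(C)c([C@H](OC(C)(C)C)C(=O)O)c(N2CCC(C)(C)CC2)c1-c1ccc(OC2COCC2c2ccc(F)cc2)cc1` differs from compound 2 by 4-(4-fluorophenyl)oxolan-3-yl in place of 2-(2,4-difluorophenyl)ethyl on an oxygen on an aromatic ring. Within the data shown here, three measured steps touch this region of the molecule: a step that the two limits leave unreadable from compound 1 to compound 2, a step that the two limits leave unreadable from compound 1 to compound 3 and a step that the two limits leave unreadable from compound 2 to compound 3. Each of them stays unreadable because of the limit of > 2 h in this assay, at which 3 of the 3 values shown sit, so no size and no direction can be taken from them. The one thing they do show is that three different groups hanging from the same oxygen on the aromatic ring all left the shared core at the limit. On that basis compound 4 is expected to sit at the same limit, and the step from compound 2 is estimated as a step that the limit leaves unreadable from compound 2 to compound 4. The estimate for compound 4 in this assay is 2.5 h, with a range from 1 h to 5 h.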

Compound 4, half-life: > 2 h
Compound 4 gave a limit, no number (the forecaster's own chance of this, stated with the estimate: 70%); the middle value lies beyond the limit too.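

Compound 4 also sits at a limit rather than a number, so the steps to it from compound 1 and compound 2 cannot be read, because no compound offers a number to compare: the limit of > 2 h in this assay, at which 4 of the 4 values shown sit.

The compounds shown leave open how long any of the four really lasts in this assay, and whether the groups on the oxygen on the aromatic ring differ at all.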